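The source may hold more compounds than are shown below. What is called first, only, known or untested is meant among the compounds shown, and "the series" means these compounds.

Of the compounds shown here, three sharing one core have been tested in an ADME assay on isolated protein for inhibition of Amine oxidase [flavin-containing] A (Homo sapiens), read by fluorescence and Amplex Red, with stated times of 15 min and 20 min; a lower number here means a stronger inhibitor, a higher number a weaker inhibitor. Compound 1, `C#CCN(CCCOc1ccc2ccc(=O)oc2c1)Cc1ccc(OC)cc1`, gives 60000 nM. Compound 2, `C#CCN(C)CCCOc1ccc2ccc(=O)oc2c1`, carries only hydrogen where compound 1 carries a 4-methoxyphenyl group, and compound 2 gives 36900 nM; the change is a 1.6-fold lower number from compound 1 to compound 2 (0.21 log units; within the scatter). Compound 3, `C#CCN(CCCOc1ccc2ccc(=O)oc2c1)Cc1ccc(C(C)C)cc1`, gives 77400 nM. Its number is separated beyond the scatter only from compound 2, by a 2.1-fold higher number from compound 2 to compound 3 (0.32 log units; beyond the scatter), while against compound 1 the gap is a 1.3-fold higher number from compound 1 to compound 3 (0.11 log units; within the scatter), so compound 3 and compound 1 cannot be told apart here.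

The next compound, compound 4, `C#CCN(CCCOc1ccc2ccc(=O)oc2c1)Cc1cccc(OC)c1`, has not yet been measured. It differs from compound 3 in one place: 3-methoxyphenyl in place of 4-isopropylphenyl on a saturated chain carbon bound to an amine nitrogen. Within the data shown here, the step that bears most on this is the one from compound 1 to compound 3, where isopropyl replaced methoxy on the aromatic carbon and the number moved by a 1.3-fold higher number from compound 1 to compound 3 (0.11 log units; within the scatter), within the scatter. Going back from isopropyl to methoxy should therefore cost little either way; the shift of the methoxy group to the 3-position has no precedent among these compounds, so nothing can be drawn for it. The step from compound 3 to compound 4 is thus expected to be about a 1.3-fold lower number from compound 3 to compound 4 (0.11 log units; within the scatter), with no direction beyond the scatter. Compound 4 is estimated to give 60000 nM in this assay, with a range from 30000 nM to 120000 nM.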

Compound 4, half-maximal inhibitory concentration: 22700 nM
The estimate for compound 4 lay 2.6-fold (0.42 log units) above the measured number; measured number outside the range, below it.
By their numbers in this assay, from the lowest: compounds 4, 2, 1 and 3 (each within the scatter of the next, the first and the last beyond it).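

At the saturated chain carbon bound to an amine nitrogen, the place of the methoxy group on the aromatic ring matters in this assay: 3-methoxyphenyl in place of 4-methoxyphenyl gives a 2.6-fold lower number from compound 1 to compound 4 (0.42 log units; beyond the scatter) even though the same group has only moved on the ring. Among these compounds, replacing 4-isopropylphenyl with 3-methoxyphenyl gives a 3.4-fold lower number from compound 3 to compound 4 (0.53 log units; beyond the scatter) and is a larger step than any seen among the earlier compounds, while putting 3-methoxyphenyl in place of hydrogen gives a 1.6-fold lower number from compound 2 to compound 4 (0.21 log units; within the scatter) so that compound 4 and compound 2 cannot be told apart here. This means that an aromatic ring at this place does not by itself separate these compounds from compound 2, and that compounds 1 and 3 stand apart from compound 4 in this assay, but nothing measured here offers an explanation for the shift.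

The compounds shown cannot say whether the result belongs to the methoxy group itself or to any group at that place on the ring, and a 3-isopropylphenyl group would help to separate the two. From the compounds shown here alone, how a fluorine, a nitrile or a carboxylic acid on the same ring would behave also remains open.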